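A Diarylamine Replaces the Triflate on a Shared Core

The source may hold more compounds than are shown below. What is called first, only, known or untested is meant among the compounds shown, and "the series" means these compounds.

In a functional assay on NALM-6 cells (Homo sapiens) for cytotoxicity, with a stated time of 72 h (on this read-out lower numbers stand for an effect already at smaller amounts and higher numbers for an effect only at larger amounts of compound), compound 1 `C=C[C@@](C)(/C=C/c1ccc(OS(=O)(=O)C(F)(F)F)cc1)CCC=C(C)C` gives only a limit of the assay, > 43400 nM. Compound 2 `C=C[C@@](C)(/C=C/c1ccc(OS(=O)(=O)c2ccc(C)cc2)cc1)CCC=C(C)C` likewise gives only a limit, > 43400 nM. Compound 3 `C=C[C@@](C)(/C=C/c1ccc(O)c(/C=C/C#N)c1)CCC=C(C)C` too gives only a limit, > 43400 nM. Within the data shown here, the one measured step, a step that the two limits leave unreadable from compound 1 to compound 2, is therefore unreadable, and the whole of the measured picture is the limit of > 43400 nM in this assay, at which 3 of the 3 values shown sit. Compound 1 thus stands at the limit together with every other measured compound, with no number to place it.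

Compound 4 `C=C[C@@](C)(/C=C/c1ccc(Nc2ccc(Cl)c(Cl)c2)cc1)CCC=C(C)C` differs from compound 1 in one place: (3,4-dichlorophenyl)amino in place of ((trifluoromethyl)sulfonyl)oxy on an aromatic carbon. Among the measured compounds shown here, no measured step bears on this change, since the only measured pair exchanges one sulfonyl substituent for another and both ends sit at the limit; the sole hydrogen-bond donor among the four compounds other than the phenol of compound 3 enters here. Without a readable step, the direction of the change in this assay cannot be inferred from the data, and a result at the limit remains plausible.

Compound 4 is estimated at 15000 nM, within a range from 2000 nM to 60000 nM. The step from compound 1 to compound 4 is accordingly expected to be an at least 2.8-fold lower number from compound 1 to compound 4 (0.46 log units; beyond the scatter).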

Compound 4, half-maximal effective concentration: > 43400 nM
Compound 4: a limit, no number; the forecaster's own chance of this, stated with the estimate: 35%; at least 2.8-fold (0.46 log units) between middle value and limit.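

Compound 4, like compound 1, gives only a limit in this assay, so the step between the two cannot be read: the limit of > 43400 nM in this assay, at which 4 of the 4 values shown sit. The compounds shown leave open whether any change on the shared core yields a measured number rather than a limit.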